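A few compounds are considered here, and "the series" means these few. Any claim that something is new, unique, unknown or untested is made for them only; others in the source may bear on it.

Going by the values given here, compound 2 `NC(=O)c1c(NC(=O)c2ccccc2Cl)sc2c1CCN(Cc1cc(Cl)cc(Cl)c1)C2` is the only compound of this pair with a definite number: in a functional assay on MKN-74 cells (Homo sapiens) for antiproliferative activity, with a stated time of 24 h (a lower number here means a stronger inhibitor, a higher number a weaker inhibitor), compound 2 gives 23700 nM. Compound 1 `Cc1ccccc1CN1CCc2c(sc(NC(=O)c3ccccc3Cl)c2C(N)=O)C1` carries 2-methylphenyl where compound 2 carries 3,5-dichlorophenyl. In this assay compound 1 gives > 50000 nM, which is a limit of the assay and not a number (the limit of > 50000 nM in this assay, at which 1 of the 2 values shown sits). Among the compounds with values here, the single measured step, an at least 2.1-fold lower number from compound 1 to compound 2 (0.32 log units; beyond the scatter), is thus itself bounded on one side and concerns only the aryl group hung from the same ring nitrogen. Compound 3 `NC(=O)c1c(NC(=O)c2ccccc2Cl)sc2c1CCN(C(=O)Nc1ccccc1Cl)C2` differs from compound 2 in one place: (2-chlorophenyl)carbamoyl in place of 3,5-dichlorobenzyl on an amine nitrogen in a ring. Within the data shown here, no measured step covers a swap of a benzyl for a carbamoyl group; the one step shows only that this position can shift the number by a modest amount. Compound 3 is therefore expected to stay weak, with an estimated step of a 1.1-fold higher number from compound 2 to compound 3 (0.02 log units; within the scatter) from compound 2, and an estimated value of 25000 nM, within a range of 8000 nM to 60000 nM.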

Compound 3, half-maximal inhibitory concentration: 16300 nM
For compound 3 the middle estimate is 1.5-fold (0.19 log units) above the measured one; the measured number falls inside the stated range.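

In this assay, replacing the benzyl group with (2-chlorophenyl)carbamoyl on the amine nitrogen in the ring gives a 1.5-fold lower number from compound 2 to compound 3 (0.16 log units; within the scatter), so a change of the link itself, and not only of the aryl group, leaves the number within the scatter at this position. The other step available, an at least 3.0-fold lower number from compound 1 to compound 3 (0.48 log units; beyond the scatter), places compound 3 beyond the scatter of compound 1, as compound 2 already was. That step is bounded on one side, since compound 1 stands at a limit and not at a number: the limit of > 50000 nM in this assay, at which 1 of the 3 values shown sits.

Still open, as far as these compounds go, is whether an amine or a carboxylic acid carried by the group on this nitrogen, or a longer chain there, would move the number beyond the scatter of compound 2 and compound 3. Going by these compounds alone, the chlorine pattern and the carbonyl link also remain unseparated, since both change in the single swap from compound 2 to compound 3.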